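Benzamide in place of the urea on the shared core

A few compounds are considered here, and "the series" means these few. Any claim that something is new, unique, unknown or untested is made for them only; others in the source may bear on it.

The series rests on the shared core of compound 1, `O=C(Nc1cccc(-n2cc(-c3ccncc3)c(-c3ccc(Cl)c(O)c3)n2)c1)Nc1cccc(C(F)(F)F)c1`, and compound 2, `COc1cc(-c2nn(-c3cccc(NC(=O)Nc4cccc(C(F)(F)F)c4)c3)cc2-c2ccncc2)ccc1Cl`. In a functional assay on TK-10 cells (Homo sapiens) for inhibition, read by sulforhodamine B assay, with a stated time of 48 h (a higher number here means that more compound is tolerated, a lower number that less compound is tolerated), compound 1 gives only a limit of the assay, > 32500 nM. In this assay compound 2 likewise gives only a limit of the assay, > 50000 nM. For the measured compounds named here, the single measured step, a step that the two limits leave unreadable from compound 1 to compound 2, is methyl in place of hydrogen on an oxygen on an aromatic ring, and its size cannot be read. Compound 2 therefore stands at a limit rather than at a number in this assay. Compound 3, `COc1cc(-c2nn(-c3cccc(NC(=O)c4ccccc4)c3)cc2-c2ccncc2)ccc1Cl`, differs from compound 2 by phenyl in place of (3-(trifluoromethyl)phenyl)amino on a carbonyl carbon. No measured step touches the carbonyl carbon, so nothing shown bears on this change. Compound 3 is expected to remain tolerated up to the limit, with an estimated step of a number no higher from compound 2 to compound 3 (the limit leaves the size open). The estimate for compound 3 in this assay is 50000 nM, between 15000 nM and 100000 nM.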

Compound 3, concentration lethal to 50% of the cells: > 100000 nM
Compound 3: only a limit was reported; the forecaster's own chance of this, stated with the estimate: 70%; middle value at least 2.0-fold (0.30 log units) from the limit.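

In this assay compound 3 gives only a limit of the assay, > 100000 nM; compound 2 also stands at a limit, so the step between them cannot be read. The compounds shown leave open whether compound 1, compound 2 and compound 3 differ at all in this assay.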